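The compounds below may be only part of what the source reports. "The series", "measured", "known", "first", "only" and "open" are said of these compounds alone.

Working notes on the series

The compounds share one core and differ only in the aromatic group on a double-bonded chain carbon bound to a double-bonded ring carbon. Compound 1 `CCOC(=O)C1=C(Nc2ccccc2)S/C(=C\c2ccc(OC)cc2)C1=O` carries 4-methoxyphenyl there; in a functional assay on K562 cells (Homo sapiens) for inhibition, read by MTT assay, with a stated time of 72 h, tested at 10 uM (on this read-out lower numbers stand for less inhibition and higher numbers for more inhibition at the one concentration tested (going by the name of the read-out)), compound 1 gives 9.6%. Compound 2 `CCOC(=O)C1=C(Nc2ccccc2)S/C(=C\c2cc[nH]c2)C1=O` carries 1H-pyrrol-3-yl there; in this assay compound 2 gives 18.9%. The step of a number 9.3 percentage points higher from compound 1 to compound 2 (within the scatter) is the only one measured so far. On the numbers shown, compound 2 and compound 1 sit together at the weak end of the read-out, with no gap beyond the scatter between them.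

Compound 3 `CCOC(=O)C1=C(Nc2ccccc2)S/C(=C\c2cccnc2)C1=O` is not yet measured. Its change from compound 2 is pyridin-3-yl in place of 1H-pyrrol-3-yl on a double-bonded chain carbon bound to a double-bonded ring carbon. For the measured compounds named here, the one step that bears on it, a number 9.3 percentage points higher from compound 1 to compound 2 (within the scatter), shows that exchanging the aromatic group at this position has so far moved the read-out only within the scatter, so the expectation for compound 3 is a step of a number 3.9 percentage points lower from compound 2 to compound 3 (within the scatter) with no clear direction and no size beyond the scatter. The estimate for compound 3 is 15%, with a range from 3% to 30%.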

Compound 3, a percentage reported as inhibition, at one concentration (the size of the read-out at that concentration, not a potency): < 10%
Compound 3: a limit, no number; the forecaster's own chance of this, stated with the estimate: 5%; at least 5 percentage points between middle value and limit.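

In this assay, compound 3 is reported as a limit and not as a number: the limit of < 10% in this assay, at which 1 of the 3 values shown sits.

Pyridin-3-yl in place of 1H-pyrrol-3-yl on a double-bonded chain carbon bound to a double-bonded ring carbon gives a number at least 8.9 percentage points lower from compound 2 to compound 3 (that floor lies within the scatter). This adds a six-membered aromatic ring with a hetero atom to the groups tried at this position, yet every step that can be read there still shows no change beyond the scatter, while the step from compound 1 to compound 3 cannot be read.

The limit leaves open whether the true gap between the pyridin-3-yl and 1H-pyrrol-3-yl compounds lies beyond the scatter. The compounds shown also leave open whether an amine or a carboxylic acid on the aromatic group, or a longer chain carrying that group away from the double-bonded ring carbon, would lift the read-out clear of the scatter.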